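Thiophene amide to phenyl carbamate: an untested carbonyl swap

A few compounds are considered here, and "the series" means these few. Any claim that something is new, unique, unknown or untested is made for them only; others in the source may bear on it.

Compound 1, `COc1ccc(C(=O)Nc2cccc3c2N(S(=O)(=O)c2ccc(OC)cc2)CC3)cc1`, gives 2600 nM in a functional assay on KB cells (Homo sapiens) for cytotoxicity; a higher number here means a weaker inhibitor, a lower number a stronger inhibitor.
Compound 2, `COc1ccc(S(=O)(=O)N2CCc3cc(Br)cc(NC(=O)c4ccncc4)c32)cc1`, gives 91 nM in this assay.
Compound 3, `COc1ccc(S(=O)(=O)N2CCc3cccc(NC(=O)c4cccs4)c32)cc1`, gives 47 nM in this assay.

Compound 3 has the lowest number of the three in this assay; compound 2 lies within the scatter of it, while compound 1 lies well beyond. Compound 4, `COc1ccc(S(=O)(=O)N2CCc3cccc(NC(=O)Oc4ccccc4)c32)cc1`, differs from compound 3 in one place: phenoxy in place of thiophen-2-yl on a carbonyl carbon. Going by the values given here, the only measured step at this carbonyl carbon is a 55-fold lower number from compound 1 to compound 3 (1.74 log units; beyond the scatter), a large one, so changes here have moved the number strongly. Among the compounds with values here, no measured pair exchanges an amide for a carbamate, so the direction is open. Compound 4 is therefore expected to give about 300 nM, between 60 nM and 1500 nM. The expected step is a 6.4-fold higher number from compound 3 to compound 4 (0.81 log units; beyond the scatter).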

Compound 4, half-maximal inhibitory concentration: > 10000 nM
Compound 4 was reported as a limit; the forecaster's own chance of this, stated with the estimate: 5%; middle value at least 33-fold (1.52 log units) from the limit.
By their numbers in this assay, from the lowest: compounds 3 and 2 (each within the scatter of the next); then compound 1. At a limit, above all of these: compound 4.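

The value of compound 4 is a limit and not a number: the limit of > 10000 nM in this assay, at which 1 of the 4 values shown sits. On this carbonyl carbon, phenoxy gives an at least 210-fold higher number from compound 3 to compound 4 (2.32 log units; beyond the scatter), and it also gives an at least 3.8-fold higher number from compound 1 to compound 4 (0.58 log units; beyond the scatter). The position therefore tolerates neither swap equally: thiophen-2-yl and 4-methoxyphenyl both give measurable numbers, while phenoxy reaches the limit, so this single change can abolish a measurable response in this assay.

On these data alone, how far compound 4 actually lies from compound 3 stays open. So does whether an anilino group, giving a urea, or a benzyl group on the same carbonyl carbon would keep the number low.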